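A few compounds are considered here, and "the series" means these few. Any claim that something is new, unique, unknown or untested is made for them only; others in the source may bear on it.

Measured so far:
compound 1, `Cn1ccc2ccc(-c3cc(Nc4cnccc4C(=O)NCc4cncnc4)cc4nccnc34)cc21`, in an assay on lysate for inhibition of 6-phosphofructo-2-kinase/fructose-2,6-bisphosphatase 3 (Homo sapiens), with stated times of 0.5 min and 45 min; on this read-out lower numbers stand for stronger inhibition and higher numbers for weaker inhibition: 49500 nM
compound 2, `Cn1cc(NC(=O)c2ccncc2Nc2cc(-c3ccc4ccn(C)c4c3)c3nccnc3c2)cn1`, in this assay: 26500 nM
compound 3, `CN1CCC(NC(=O)c2ccncc2Nc2cc(-c3ccc4ccn(C)c4c3)c3nccnc3c2)CC1`, in this assay: 19500 nM

Compound 3 has the lowest of the three numbers in this assay. Its separation from compound 2, a 1.4-fold lower number from compound 2 to compound 3 (0.13 log units; within the scatter), lies within the scatter, so the two cannot be ordered; only against compound 1 is the step clear, a 2.5-fold lower number from compound 1 to compound 3 (0.40 log units; beyond the scatter). The other measured step, a 1.9-fold lower number from compound 1 to compound 2 (0.27 log units; within the scatter), is also within the scatter. All three exchanges replace the whole group on the amide-type nitrogen and move the number only modestly.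

Compound 4, `CC(=O)N1CCC(NC(=O)c2ccncc2Nc2cc(-c3ccc4ccn(C)c4c3)c3nccnc3c2)CC1`, differs from compound 3 by acetyl in place of methyl on an amine nitrogen in a ring. Within the data shown here, no measured step touches this amine nitrogen in the ring; the three steps above bear on it only as a sign that changes in this part of the molecule have so far been small. A step no larger than those is therefore expected in this assay, with no direction favoured.

Compound 4 is expected near 20000 nM, with a range from 8000 nM to 50000 nM. The estimated step, a 1.0-fold higher number from compound 3 to compound 4 (0.01 log units; within the scatter), is expected to remain within the scatter.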

Compound 4, half-maximal inhibitory concentration: 31300 nM
Estimate against measurement, compound 4: 1.6-fold (0.19 log units) below; the measured number falls inside the stated range.
By their numbers in this assay, from the lowest: compounds 3, 2, 4 and 1 (each within the scatter of the next, the first and the last beyond it).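

In this assay, the ring amine nitrogen of the piperidine-type group was shown to carry acetyl as well as methyl without a readable change (a 1.6-fold higher number from compound 3 to compound 4 (0.21 log units; within the scatter)), so compound 3 and compound 4 cannot be ordered. Compound 4 also cannot be separated from either compound with a different group on the amide-type nitrogen (a 1.2-fold higher number from compound 2 to compound 4 (0.07 log units; within the scatter); a 1.6-fold lower number from compound 1 to compound 4 (0.20 log units; within the scatter)), whereas compound 3 stands clearly apart from compound 1 (a 2.5-fold lower number from compound 1 to compound 3 (0.40 log units; beyond the scatter)). Nothing available explains this outcome.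

The compounds shown leave open how this ring nitrogen would read with a free hydrogen, a methanesulfonyl group or a longer chain in place of methyl or acetyl. They also leave open whether a carboxylic acid on that chain would move the number beyond the scatter.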